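The compounds below may be only part of what the source reports. "The series", "measured", "known", "first", "only" and "open" are said of these compounds alone.

Compound 1 `C=CCn1c(=O)/c(=C\c2ccccc2Cl)[nH]c(=O)/c1=C\c1ccccc1OC`: 9200 nM
Compound 2 `COc1ccccc1/C=c1\c(=O)[nH]/c(=C/c2cccc(Cl)c2Cl)c(=O)n1C`: 300 nM

In a functional assay on NCI-H1975 cells (Homo sapiens) for cytotoxicity, read by CCK-8 assay, with a stated time of 72 h (on this read-out lower numbers stand for stronger inhibition and higher numbers for weaker inhibition), compound 2 holds the lower of the two numbers at 300 nM, and compound 1 gives the higher number at 9200 nM. The gap between these two numbers lies beyond the scatter. Compound 3 `COc1ccccc1/C=c1\c(=O)[nH]/c(=C/c2ccccc2Cl)c(=O)n1C` is not yet measured. It departs from compound 2 by hydrogen in place of chloro on an aromatic carbon, so that 2,3-dichlorophenyl becomes 2-chlorophenyl. Going by the values given here, no measured step isolates this change, so the expectation is tentative. Compound 1, which also carries the 2-chlorophenyl group, gives 9200 nM as the only hint, and a move towards a higher number in this assay is expected. The expected size is a 3.3-fold higher number from compound 2 to compound 3 (0.52 log units; beyond the scatter) as estimated. Compound 3 is estimated at 1000 nM with an expected range of 300 nM to 3500 nM in this read-out.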

Compound 3, half-maximal inhibitory concentration: 200 nM
The estimate for compound 3 lay 5.0-fold (0.70 log units) above the measured number; measured number outside the range, below it.
By their numbers in this assay, from the lowest: compounds 3 and 2 (each within the scatter of the next); then compound 1.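

In this assay, the change from 2,3-dichlorophenyl to 2-chlorophenyl reads a 1.5-fold lower number from compound 2 to compound 3 (0.18 log units; within the scatter) and so does not separate the two groups. The other step, hydrogen in place of vinyl on the saturated chain carbon bound to the aromatic nitrogen, reads a 46-fold lower number from compound 1 to compound 3 (1.66 log units; beyond the scatter) and is large. Among the steps that can be read, the chain on the aromatic nitrogen is therefore the place with a difference beyond the scatter, while the loss of this chloro shows none. Nothing at hand accounts for either step.

Still open, from the compounds shown here alone, is where a longer saturated chain or a chain ending in an amine on that nitrogen would fall relative to these two steps. Also open, going by these compounds, is whether fluoro in place of the remaining chloro would leave the number within the scatter.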